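Trading the phenylethenyl arm for a nitrile chain

This account rests on a few compounds, and the source may have more. Where it says the series, first, only, none or still open, it means among the compounds named here.

Of the compounds shown here, three built on one shared core have been measured in a functional assay on H4 cells for agonist activity at growth hormone secretagogue receptor type 1 (Homo sapiens), read by FLIPR; a lower number here means that less compound is needed, a higher number that more compound is needed for the effect. Compound 1 `CC(C)(N)C(=O)N[C@H](COCc1ccccc1)c1nnn(Cc2cccc(NS(C)(=O)=O)c2)n1` gives 868 nM. Compound 2 `CC(C)(N)C(=O)N[C@H](COCc1ccccc1)c1nnn(CC2Cc3ccccc3N2S(C)(=O)=O)n1` gives 546 nM. Compound 3 `CC(C)(N)C(=O)N[C@H](COCc1ccccc1)c1nnn(C/C=C/c2ccccc2)n1` gives 517 nM; this is the lowest of the three numbers, but its gap to compound 2 and its gap to compound 1 both lie within the scatter, so no ranking among the three can be drawn. Among the measured compounds shown here, the single one-point step among them, a 1.7-fold lower number from compound 1 to compound 3 (0.23 log units; within the scatter), is likewise within the scatter.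

Compound 4 `CC(C)(N)C(=O)N[C@H](COCc1ccccc1)c1nnn(CCCCC#N)n1` differs from compound 3 in one place: 3-cyanopropyl in place of 2-phenylethenyl on a saturated chain carbon bound to an aromatic nitrogen. For the measured compounds named here, the step from compound 1 to compound 3 is the only measured step at this position, and it exchanged one ring-bearing arm for another without moving the number beyond the scatter. Going by the values given here, the change to compound 4 is of a different kind, since the six-membered aromatic ring leaves entirely and a nitrile enters; no measured pair tests that. With every measured variant at this position carrying an aromatic ring, the expectation is that the number rises somewhat, by a 2.3-fold higher number from compound 3 to compound 4 (0.37 log units; beyond the scatter). Compound 4 is therefore estimated to give about 1200 nM in this assay, with a range from 400 nM to 4000 nM.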

Compound 4, half-maximal effective concentration: 1860 nM
For compound 4 the middle estimate is 1.6-fold (0.19 log units) below the measured one; the range from low to high includes it.
By their numbers in this assay, from the lowest: compounds 3, 2 and 1 (each within the scatter of the next); then compound 4.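

In this assay, among the compounds shown here, this is the first step at the saturated chain carbon bound to an aromatic nitrogen that lies beyond the scatter: a 3.6-fold higher number from compound 3 to compound 4 (0.56 log units; beyond the scatter) when 3-cyanopropyl, with no ring, replaces 2-phenylethenyl, with its six-membered aromatic ring of carbon only. The comparison with the other ring-bearing arm points the same way, a 2.1-fold higher number from compound 1 to compound 4 (0.33 log units; beyond the scatter) when 3-cyanopropyl replaces 3-(methanesulfonamido)phenyl, so the number at this position does respond to the arm, although both steps are modest and the ring-bearing arms of compound 1 and compound 3 remain within the scatter of each other. Nothing available gives a reason for this higher number.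

The change to compound 4 removes the ring and brings in the nitrile at once, so these compounds cannot show which of the two accounts for the step. A plain butyl chain would separate the two, while a benzyl group carrying a nitrile, or a chain ending in an amine or a carboxylic acid, would show how far the position tolerates other arms.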